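Three Level Values and a Fluorinated Newcomer

This account rests on a few compounds, and the source may have more. Where it says the series, first, only, none or still open, it means among the compounds named here.

Measured so far in a physicochemical assay for acid dissociation:
Compound 1 `Cc1cc(Cl)ccc1Nc1cc(C(F)(F)F)c(C(=O)NCC2CCOCC2)cn1` gives 2.63
Compound 2 `O=C(NCC1CCOCC1)c1cnc(Nc2ccc(Cl)cc2Cl)cc1C(F)(F)F` gives 2.63
Compound 3 `COc1ccc(Cl)cc1Nc1cc(C(F)(F)F)c(C(=O)NCC2CCOCC2)cn1` gives 2.63

Level with compounds 1 and 2, compound 3 stands at 2.63 in this assay, so it marks neither end of a range. The next compound, compound 4 `O=C(NCC1CCOCC1)c1cnc(Nc2cccc(F)c2)cc1C(F)(F)F`, keeps the shared core and the amide side chain. It carries 3-fluorophenyl in place of 5-chloro-2-methoxyphenyl on a nitrogen on an aromatic ring, and the count of that exchange reads (3-fluorophenyl in place of 5-chloro-2-methoxyphenyl on a nitrogen on an aromatic ring).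

Among the compounds with values here, three measured steps bear on this change, and each alters only the substituted phenyl group on that nitrogen. They are no change at the digits printed from compound 1 to compound 2 (within the scatter), then no change at the digits printed from compound 1 to compound 3 (within the scatter), and finally no change at the digits printed from compound 2 to compound 3 (within the scatter). None of them moved the read-out at all. Within the data shown here, still, no measured compound carries 3-fluorophenyl, and every measured compound has a chloro group on its phenyl ring, so the comparison is not a complete one.

On the strength of no change at the digits printed from compound 2 to compound 3 (within the scatter), an exchange at the same nitrogen, the expected step is no change at the digits printed from compound 3 to compound 4 (within the scatter), with a higher read-out expected no more than a lower one and nothing expected beyond the scatter. For compound 4 the estimated value is 2.63, with an expected range from 2.3 to 2.95.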

Compound 4, acid dissociation constant: 2.63
Estimate against measurement, compound 4: no gap at the digits printed; the measured number falls inside the stated range.
By their numbers in this assay, from the lowest: compounds 1, 2, 3 and 4 (each within the scatter of the next).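

Across the four compounds, the exchange at this nitrogen leaves the read-out in this assay flat: the newcomer shows no change at the digits printed from compound 3 to compound 4 (within the scatter), along with no change at the digits printed from compound 2 to compound 4 (within the scatter) and no change at the digits printed from compound 1 to compound 4 (within the scatter). Every earlier compound had a chloro group on its phenyl ring, so this result extends the flat picture to a ring without chlorine, one carrying fluorine alone, and to a smaller group, with 3-fluorophenyl at 7 heavy atoms where 5-chloro-2-methoxyphenyl has 9, and without the one hydrogen-bond acceptor of the group it replaces. Nothing measured in this set offers an explanation for the flat read-out at this position.

On these data alone, it remains open whether the read-out would stay level with a phenyl ring bearing an amine or a carboxylic acid, or with a longer alkyl chain in place of the phenyl ring on that nitrogen. As far as these compounds go, all four compounds also keep the trifluoromethyl group and the amide side chain, so the effect of an exchange at either of those places on this read-out is unknown.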